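A few compounds are considered here, and "the series" means these few. Any claim that something is new, unique, unknown or untested is made for them only; others in the source may bear on it.

Measured compounds in a functional assay on HepG2 cells (Homo sapiens) for antiproliferative activity, read by MTT assay, with a stated time of 48 h; on this read-out lower numbers stand for stronger inhibition and higher numbers for weaker inhibition:

compound 1 `Cc1cc(C)cc(-n2nncc2CN2C(=O)C3(C(C#N)=C(N)Oc4c3c3nc5ccccc5nc3c3ccccc43)c3ccccc32)c1`: > 50000 nM
compound 2 `Cc1ccc(-n2nncc2CN2C(=O)C3(C(C#N)=C(N)Oc4c3c3nc5ccccc5nc3c3ccccc43)c3ccccc32)cc1Cl`: > 50000 nM
compound 3 `Cc1cccc(-n2nncc2CN2C(=O)C3(C(C#N)=C(N)Oc4c(N)cc5nc6ccccc6nc5c43)c3ccccc32)c1`: > 50000 nM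

Each of these values is a limit of the assay, not a number. Compound 3 stands at the limit > 50000 nM in this assay; the two other values shown are likewise limits, so compound 3 cannot be placed against them beyond saying that all three sit together at the limit (the limit of > 50000 nM in this assay, at which 3 of the 3 values shown sit).

The step to compound 4 `Cc1cc(C)cc(-n2nncc2CN2C(=O)C3(C(C#N)=C(N)Oc4c(N)cc5nc6ccccc6nc5c43)c3ccccc32)c1` is methyl in place of hydrogen on an aromatic carbon. Read one bond further out, this is 3-methylphenyl to 3,5-dimethylphenyl on the aromatic nitrogen. Within the data shown here, the only measured step, a step that the two limits leave unreadable from compound 1 to compound 2, is likewise a change of the aryl group on that aromatic nitrogen, and its size cannot be read because both ends sit at the limit. Among the measured compounds shown here, no measured step therefore speaks for any shift in this assay on adding the methyl group; the same aryl group as in compound 4 is carried by compound 1 on the other core, and compound 1 also sits at the limit.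

Compound 4 is therefore expected to remain at the limit of this assay, with the estimate 70000 nM (range 20000 nM to 250000 nM). The expected step is a step that the limit leaves unreadable from compound 3 to compound 4, which is no step beyond the scatter.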

Compound 4, half-maximal inhibitory concentration: > 50000 nM
Compound 4 ended at the assay's limit; the forecaster's own chance of this, stated with the estimate: 85%; the middle value is on the limit's open side.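

Among these compounds, compound 3 and compound 4 both stand at a limit in this assay, so the step between them cannot be read and no new step comes from this result: the limit of > 50000 nM in this assay, at which 4 of the 4 values shown sit. The compounds shown leave open whether any change to the aryl group or the core moves a value off this limit.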